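Replacing tert-butyl with bromo: what to expect

The compounds below may be only part of what the source reports. "The series", "measured", "known", "first", "only" and "open" are said of these compounds alone.

Measured in a functional assay on MCF7 cells (Homo sapiens) for inhibition, read by MTT assay; on this read-out lower numbers stand for stronger inhibition and higher numbers for weaker inhibition:
Compound 1 `COc1cc2ncnc(Nc3ccc(NC(=O)c4ccc(C(C)(C)C)cc4)cc3)c2cc1OC`: > 100000 nM
Compound 2 `COc1cc2ncnc(Nc3ccc(NC(=O)c4ccc(Cl)cc4)cc3)c2cc1OC`: 30000 nM

The entry for compound 1 is a limit of the assay, not a number. This makes compound 1 a weak starting point with no exact position on the scale, and any step from it can only be given as a bound.

The next compound to be tested is compound 3 `COc1cc2ncnc(Nc3ccc(NC(=O)c4ccc(Br)cc4)cc3)c2cc1OC`. It keeps the core of compound 1 and changes one group: bromo in place of tert-butyl on an aromatic carbon. The group sits on an aromatic carbon of a six-membered aromatic ring of carbon only, para to a large group.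

Among the compounds with values here, one measured step bears on this change, an at least 3.3-fold lower number from compound 1 to compound 2 (0.52 log units; beyond the scatter). There, chloro took the place of tert-butyl at the same spot. A single step is thin support, yet it points towards a lower number in this assay for compound 3, of similar size. The expected change is an at least 3.3-fold lower number from compound 1 to compound 3 (0.52 log units; beyond the scatter). For compound 3 the estimated value is 30000 nM, with an expected range from 10000 nM to 90000 nM.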

Compound 3, half-maximal inhibitory concentration: 43000 nM
For compound 3 the middle estimate is 1.4-fold (0.16 log units) below the measured one; the measured number falls inside the stated range.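

In this assay, bromo in place of tert-butyl gives an at least 2.3-fold lower number from compound 1 to compound 3 (0.36 log units; beyond the scatter), so this position now has two replacements, chloro and bromo, that both move the number the same way from compound 1. The step between those two replacements is a 1.4-fold higher number from compound 2 to compound 3 (0.16 log units; within the scatter), which means that bromo and chloro cannot be told apart at this position, and compound 2 and compound 3 together form a single level on the scale. How far either one really lies from tert-butyl stays a bound rather than an exact size, because compound 1 has no exact position on the scale and is recorded only as a limit: the limit of > 100000 nM in this assay, at which 1 of the 3 values shown sits.

The compounds shown leave open whether the lower numbers come from losing tert-butyl, a group of 4 heavy atoms, or from gaining chloro or bromo, each of a single heavy atom, and a plain hydrogen or a methyl group at the same carbon would help to separate the two readings. Also open, going by these compounds, is whether a different kind of group here, such as an amine or a carboxylic acid, would bring the number well below the level of compound 2 and compound 3.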